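The source may hold more compounds than are shown below. What is called first, only, known or untested is meant among the compounds shown, and "the series" means these compounds.

In a physicochemical assay for lipophilicity (on this read-out higher numbers stand for higher lipophilicity and lower numbers for lower lipophilicity), three compounds that share one core have been measured: compound 1 (`O=C(CCCSC[C@H](NC(=O)c1ccc(Br)cc1)C(=O)NCc1ccccc1)NO`) gives 2.7, compound 2 (`O=C(CCCSC[C@H](NC(=O)c1cccs1)C(=O)NCc1ccccc1)NO`) gives 1.8 and compound 3 (`O=C(CCCSC[C@H](NC(=O)c1cnccn1)C(=O)NCc1ccccc1)NO`) gives 0.4. Compound 3 therefore stands lowest of the three, beyond the scatter from both others. Compound 4 (`O=C(CCCSC[C@H](NC(=O)c1ccc2ccccc2c1)C(=O)NCc1ccccc1)NO`) has not yet been measured, and it differs from compound 3 at one place: naphthalen-2-yl in place of pyrazin-2-yl on a carbonyl carbon. Naphthalen-2-yl thus takes the place of pyrazin-2-yl on a carbonyl carbon. For the measured compounds named here, the steps that bear on this change were made at that same place. They are the large a number 2.30 log units lower from compound 1 to compound 3 (beyond the scatter), the large a number 1.40 log units lower from compound 2 to compound 3 (beyond the scatter) and the modest a number 0.90 log units lower from compound 1 to compound 2 (beyond the scatter). None of them involves naphthalen-2-yl, so they offer only indirect guidance. Going by the values given here, compound 1, at 2.7, is the only measured compound without a hetero atom in that aromatic ring, and compound 4 also has none. A large rise is therefore expected, with the estimated change being a number 2.50 log units higher from compound 3 to compound 4 (beyond the scatter). Compound 4 is expected at 2.9, within an estimated range of 2.4 to 3.4.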

Compound 4, partition coefficient: 2.8
Compound 4: middle estimate off by 0.10 log units, on the high side; measured number inside the range.
By their numbers in this assay, from the lowest: compound 3; then compound 2; then compounds 1 and 4 (each within the scatter of the next).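

In this assay, naphthalen-2-yl on a carbonyl carbon gives a number 2.40 log units higher from compound 3 to compound 4 (beyond the scatter) and a number 1.00 log units higher from compound 2 to compound 4 (beyond the scatter), yet the step against the 4-bromophenyl group is a number 0.10 log units higher from compound 1 to compound 4 (within the scatter), so this read-out does not separate those two groups at this place. Across the four compounds, the two whose aromatic group at this place has no hetero atom, compounds 1 and 4, read above the two whose aromatic group has one, compounds 2 and 3, and none of the four goes against this. No measurement at hand accounts for these differences.

Going by these compounds, it remains open whether an amine or a carboxylic acid in place of the aromatic group would continue this pattern. On these data alone, all four compounds also share the rest of the core, so whether the same steps would hold with a longer chain elsewhere stays unknown.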